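Butyl in Place of Propargyl on the Triazene Nitrogen

This account rests on a few compounds, and the source may have more. Where it says the series, first, only, none or still open, it means among the compounds named here.

Compound 1 `C#CCN(C)/N=N/c1ccc(C(=O)O)cc1` carries a propargyl group on the amine nitrogen of the shared core. In a physicochemical assay for lipophilicity, in phosphate buffer, measured as octanol-water partition, at pH 7.4 (on this read-out lower numbers stand for lower lipophilicity and higher numbers for higher lipophilicity), compound 1 gives 0, the lowest of the three numbers recorded so far. Compound 2 `CC(C)N(C)/N=N/c1ccc(C(=O)O)cc1` gives 0.34 in this assay, and compound 3 `CCCCCCCN(C)/N=N/c1ccc(C(=O)O)cc1` gives 2.58. The step of a number 0.34 log units higher from compound 1 to compound 2 (beyond the scatter) is modest; the step of a number 2.58 log units higher from compound 1 to compound 3 (beyond the scatter) is large.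

Compound 4 `CCCCN(C)/N=N/c1ccc(C(=O)O)cc1` is not yet measured. Relative to compound 1 the change is propyl in place of ethynyl on a saturated chain carbon bound to an amine nitrogen. Both recorded steps bear on this: the move to compound 3 shows that lengthening the saturated chain on this carbon raises the number strongly, while the move to compound 2 shows that a saturated three-carbon group alone gives only a small rise over propargyl. Butyl lies between these two cases in chain length, so a rise well beyond the scatter but far short of the step to compound 3 is expected. For compound 4 the expected value in this assay is 1, with a range from 0.6 to 1.5, which is expected to correspond to a step of a number 1.00 log units higher from compound 1 to compound 4 (beyond the scatter).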

Compound 4, distribution coefficient: 0.97
Estimate against measurement, compound 4: 0.03 log units above; low and high end bracket the measured number.
By their numbers in this assay, from the lowest: compound 1; then compound 2; then compound 4; then compound 3.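

In this assay, butyl on the amine nitrogen stands apart from both shorter comparators: a number 0.97 log units higher from compound 1 to compound 4 (beyond the scatter), and a number 0.63 log units higher from compound 2 to compound 4 (beyond the scatter), so the earlier gap between propargyl and isopropyl is not the whole range among these small groups. At the other end, a number 1.61 log units lower from compound 3 to compound 4 (beyond the scatter), a large step set against the modest one from compound 1, so among these three compounds more of the total rise lies along the chain extension beyond butyl than in the change from propargyl to butyl. Nothing on hand gives a cause for these differences.

From the compounds shown here alone, whether a pentyl or hexyl chain would fall evenly between compound 4 and compound 3 remains open. Also open, going by these compounds, is how a terminal hydroxyl or amine on the butyl chain would shift the number in this assay.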